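A few compounds are considered here, and "the series" means these few. Any claim that something is new, unique, unknown or untested is made for them only; others in the source may bear on it.

Measured so far in a functional assay on KB cells (Homo sapiens) for antiproliferative activity, read by MTT assay, with a stated time of 48 h (a higher number here means a weaker inhibitor, a lower number a stronger inhibitor), all three values being limits and not numbers:

- Compound 1 `Cn1cc(C2=C(c3nn(CCCn4cncn4)c4ncccc34)C(=O)NC2=O)c2ccccc21`: > 100000 nM
- Compound 2 `Cn1cc(C2=C(c3nn(CCCn4cccc4)c4ncccc34)C(=O)NC2=O)c2ccccc21`: > 100000 nM
- Compound 3 `Cn1cc(C2=C(c3nn(CCCN4CCCCC4)c4ncccc34)C(=O)N(c3ccc(Cl)cc3)C2=O)c2ccccc21`: > 100000 nM

Compound 2 has only a limit, > 100000 nM. It therefore has no numerical place in the series, where the whole record is the limit of > 100000 nM in this assay, at which 3 of the 3 values shown sit.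

Compound 4 `Cn1cc(C2=C(c3nn(CCCn4ccnc4)c4ncccc34)C(=O)NC2=O)c2ccccc21` carries 1H-imidazol-1-yl in place of 1H-pyrrol-1-yl on a saturated chain carbon, three bonds along the chain from an aromatic nitrogen.

Going by the values given here, the only measured change at this place is a step that the two limits leave unreadable from compound 1 to compound 2. It gives no size to carry over, and compound 3 differs from compound 2 in more than this group. Among the compounds with values here, with the limit of > 100000 nM in this assay, at which 3 of the 3 values shown sit, as the only guide, no readable step is expected in this assay, and a further limit is the most likely report.

The estimated step, no larger than the scatter, is a number no higher from compound 2 to compound 4 (the limit leaves the size open).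

The expected value for compound 4 is 100000 nM.

The estimated range for compound 4 runs from 40000 nM to 200000 nM.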

Compound 4, half-maximal inhibitory concentration: > 100000 nM
Compound 4 gave a limit, no number; the forecaster's own chance of this, stated with the estimate: 85%; the middle value sits exactly at the limit.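

In this assay compound 4 gives > 100000 nM, a limit and not a number. The steps from compound 1 and compound 2 to compound 4 therefore cannot be read: the limit of > 100000 nM in this assay, at which 4 of the 4 values shown sit. The compounds shown leave open what size, if any, a change of group at this place has in this assay.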